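Swapping piperidin-4-yl for 4-fluorophenyl on the shared core

The source may hold more compounds than are shown below. What is called first, only, known or untested is meant among the compounds shown, and "the series" means these compounds.

Measured so far in a functional assay on MIA PaCa-2 cells (Homo sapiens) for antiproliferative activity, read by MTT assay, with a stated time of 24 h; a higher number here means a weaker inhibitor, a lower number a stronger inhibitor:
compound 1 `COc1ccc(-c2noc(-c3ccncc3)n2)cc1OC1CCCC1` gives 9330 nM
compound 2 `COc1ccc(-c2noc(C3CCNCC3)n2)cc1OC1CCCC1` gives 540 nM

Compound 2 has the lower of these two numbers, which makes it the stronger inhibitor. Compound 3 `COc1ccc(-c2noc(-c3ccc(F)cc3)n2)cc1OC1CCCC1` is not yet measured and differs from compound 2 in one group (4-fluorophenyl in place of piperidin-4-yl on an aromatic carbon). Among the compounds with values here, one measured step bears on this change (a 17-fold lower number from compound 1 to compound 2 (1.24 log units; beyond the scatter)), where piperidin-4-yl replaced pyridin-4-yl. Compound 3 again carries an aromatic ring at that place, so a large rise in this assay is expected, towards compound 1, though 4-fluorophenyl is a different group from pyridin-4-yl. The expected step is large (an 11-fold higher number from compound 2 to compound 3 (1.05 log units; beyond the scatter)). For compound 3 the estimated value is 6000 nM (range 1500 nM to 20000 nM).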

Compound 3, half-maximal inhibitory concentration: 6090 nM
Compound 3: middle estimate off by 1.0-fold (0.01 log units), on the low side, and the stated range covers the measured number.
By their numbers in this assay, from the lowest: compound 2; then compounds 3 and 1 (each within the scatter of the next).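

In this assay, 4-fluorophenyl and pyridin-4-yl give similar results (a 1.5-fold lower number from compound 1 to compound 3 (0.19 log units; within the scatter)), whereas replacing piperidin-4-yl with 4-fluorophenyl has a large effect (an 11-fold higher number from compound 2 to compound 3 (1.05 log units; beyond the scatter)). Among these three compounds, the non-aromatic piperidin-4-yl therefore stands apart from both aromatic rings, and the pyridine nitrogen is not needed to match compound 1. No measurement here explains this difference. As far as these compounds go, whether the ring nitrogen of piperidin-4-yl or the non-aromatic ring itself matters remains open. Cyclohexyl, with carbon only, would separate the two, and an open-chain amine would test whether a ring is needed.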